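Swapping chloro for methoxy: an expected shift in lipophilicity

The compounds below may be only part of what the source reports. "The series", "measured", "known", "first", "only" and "open" are said of these compounds alone.

Measured so far:
compound 1 `CN(C)c1ccc(/C=C2\CCC/C(=C\c3ccccc3[N+](=O)[O-])C2=O)cc1` in a physicochemical assay for lipophilicity; a lower number here means a more polar compound, a higher number a more lipophilic compound: 4.86
compound 2 `O=C1/C(=C/c2ccc(Cl)cc2)CCC/C1=C\c1ccc([N+](=O)[O-])cc1` in this assay: 5.08

Compound 2 holds the higher of the two numbers, but compound 1 lies within the scatter of it, so no order between them can be claimed. Compound 3 `COc1ccc(/C=C2\CCC/C(=C\c3ccc([N+](=O)[O-])cc3)C2=O)cc1` differs from compound 2 by methoxy in place of chloro on an aromatic carbon. Within the data shown here, no measured pair shows this change, so its size is not known from these compounds. The step from compound 2 to compound 3 is expected to be downward and beyond the scatter, a number 0.68 log units lower from compound 2 to compound 3 (beyond the scatter). Compound 3 is therefore estimated at 4.4, between 3.9 and 4.9.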

Compound 3, partition coefficient: 5.08
For compound 3 the middle estimate is 0.68 log units below the measured one, and the stated range ends below it.
By their numbers in this assay, from the lowest: compounds 1, 2 and 3 (each within the scatter of the next).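

In this assay methoxy in place of chloro on an aromatic carbon, para to a large group, gives no change at the digits printed from compound 2 to compound 3 (within the scatter) and so puts a first measured size on this change. At this position on the shared core, 4-chlorophenyl and 4-methoxyphenyl cannot be told apart in this read-out. Nothing available explains why the two groups read alike.

From the compounds shown here alone, whether a carboxylic acid or a longer chain at this position would also stay within the scatter remains open. So does whether the same swap reads alike on a different core.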